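Closing the Distal Amide: From Cyclohexylamino to Piperidinyl

The source may hold more compounds than are shown below. What is called first, only, known or untested is meant among the compounds shown, and "the series" means these compounds.

Measured compounds:
- compound 1 `CC1CCCN1C1CCN(c2ccc(NC(=O)NC3CCCCC3)cc2)C1`: 4.1 nM
- compound 2 `Cc1cc(NC(=O)NC2CCCCC2)ccc1N1CCC(N2CCCC2C)C1`: 11.2 nM

Within the data shown here, in an assay on CHO cells for displacement of a labelled ligand from histamine receptor H3 (Macaca mulatta), read by scintillation counting, with a stated time of 1 h (a higher number here means a weaker inhibitor, a lower number a stronger inhibitor), compound 1 gives 4.1 nM, the lowest of the two numbers measured so far. Its nearest neighbour is compound 2, which differs by a methyl in place of hydrogen on an aromatic carbon and gives 11.2 nM; that step, a 2.7-fold higher number from compound 1 to compound 2 (0.44 log units; beyond the scatter), is modest but beyond the scatter.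

Compound 3 `CC1CCCN1C1CCN(c2ccc(NC(=O)N3CCCCC3)cc2)C1` is not yet measured. It differs from compound 1 by piperidin-1-yl in place of cyclohexylamino on a carbonyl carbon; cut one bond further out, the change reads cyclohexylcarbamoyl to (piperidin-1-yl)carbonyl. Among the measured compounds shown here, neither measured step touches this part of the shared core, so no measured step bears on it directly, and the expectation rests on the structural change alone. A modest weakening is expected, a 2.4-fold higher number from compound 1 to compound 3 (0.39 log units; beyond the scatter), with wide uncertainty. Compound 3 is therefore estimated at 10 nM in this assay, within a range of 2.5 nM to 40 nM.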

Compound 3, inhibition constant: 6 nM
Compound 3: middle estimate off by 1.7-fold (0.22 log units), on the high side; measured number inside the range.
By their numbers in this assay, from the lowest: compounds 1, 3 and 2 (each within the scatter of the next, the first and the last beyond it).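

Placing piperidin-1-yl instead of cyclohexylamino on the carbonyl carbon gives, in this assay, a result that stays within the scatter (a 1.5-fold higher number from compound 1 to compound 3 (0.17 log units; within the scatter)). Among these compounds, this is the first measured change at this end of the molecule, and it shows that the hydrogen-bond donor counted on cyclohexylamino, absent from piperidin-1-yl, can go with no shift beyond the scatter in this assay, while the ring stays six-membered. Nothing measured alongside these compounds offers an explanation for this result.

On these data alone, what a dimethylamino group or a morpholin-4-yl ring would do on the same carbonyl carbon stays open. So does whether methyl in place of hydrogen on an aromatic carbon, the change seen earlier (a 2.7-fold higher number from compound 1 to compound 2 (0.44 log units; beyond the scatter)), would act alike with piperidin-1-yl present.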